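The source may report more compounds than this note shows. Statements on the series, on what has been measured and on what is new or still open speak of the compounds shown alone.

Working notes on the series. Compound 1 `Cc1c[se]c(N/N=C/c2ccc(Cl)cc2)n1` gives 49400 nM in a functional assay on DU-145 cells (Homo sapiens) for cytotoxicity, read by XTT assay, with a stated time of 72 h; on this read-out lower numbers stand for stronger inhibition and higher numbers for weaker inhibition. Compound 2 `ClCc1c[se]c(N/N=C/c2ccc(Cl)cc2)n1` reaches only the limit of > 75000 nM in this assay. Compound 3 `CC(=O)N(/N=C/c1ccc(Cl)cc1)c1nc(C)c[se]1` gives 60600 nM in this assay, the highest of the two numbers, with compound 1 nearest at a 1.2-fold higher number from compound 1 to compound 3 (0.09 log units; within the scatter). Compound 4 `CC(=O)N(/N=C/c1ccc(Cl)cc1)c1nc(CCl)c[se]1` differs from compound 3 by chloro in place of hydrogen on a saturated chain carbon bound to an aromatic carbon. Among the measured compounds shown here, the one measured step of this kind is an at least 1.5-fold higher number from compound 1 to compound 2 (0.18 log units; that floor lies within the scatter), which runs into the limit of > 75000 nM in this assay, at which 1 of the 3 values shown sits, and so sets only a floor. The same change on compound 3 is therefore expected to give a step of a 1.4-fold higher number from compound 3 to compound 4 (0.15 log units; within the scatter), towards a higher number, though not shown to exceed the scatter. Compound 4 is accordingly estimated at 85000 nM, within 45000 nM to 160000 nM.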

Compound 4, half-maximal inhibitory concentration: 64700 nM
Estimate against measurement, compound 4: 1.3-fold (0.12 log units) above; measured number inside the range.
By their numbers in this assay, from the lowest: compounds 1, 3 and 4 (each within the scatter of the next). At a limit, above all of these: compound 2.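

Methyl to chloromethyl now has a step with a number at both ends, a 1.1-fold higher number from compound 3 to compound 4 (0.03 log units; within the scatter), whereas the earlier step on the core of compound 1 ended at a limit. Compound 2 gives > 75000 nM, which is a limit. Acetyl on the chloromethyl pair reads an at least 1.1-fold lower number from compound 2 to compound 4 (0.06 log units; that floor lies within the scatter), so in this assay neither change is shown to exceed the scatter on either core: the same change on two cores in this assay, a 1.2-fold higher number (0.09 log units; within the scatter) from compound 1 to compound 3 and an at least 1.1-fold lower number (0.06 log units; that floor lies within the scatter) from compound 2 to compound 4; the limit leaves it open whether they differ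

The compounds shown leave open how an amine or a longer chain on this saturated chain carbon would read in this assay. From the compounds shown here alone, the number behind the limit of compound 2 also stays open.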